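The compounds below may be only part of what the source reports. "The series", "measured", "known", "first", "only" and "open" are said of these compounds alone.

In an ADME assay on Vero cells (Chlorocebus sabaeus) for cytotoxicity, read by MTT assay, with a stated time of 48 h (on this read-out higher numbers stand for weaker inhibition and lower numbers for stronger inhibition), compound 3 `Cc1ccc(C(=O)OC2CCC(CN3CCN(c4cc(=O)c5cc(C(F)(F)F)cc([N+](=O)[O-])c5s4)CC3)CC2)cc1` gives only a limit of the assay, > 64 ug/mL. Compound 1 `O=C(OC1CCC(CN2CCN(c3cc(=O)c4cc(C(F)(F)F)cc([N+](=O)[O-])c4s3)CC2)CC1)C1CCC1` likewise reaches only a limit in this assay, > 64 ug/mL. Compound 2 `O=c1cc(N2CCN(CC3CCC(OS(=O)(=O)c4cccnc4)CC3)CC2)sc2c([N+](=O)[O-])cc(C(F)(F)F)cc12` also returns a limit, > 64 ug/mL. For the measured compounds named here, all three readings sit at the limit of > 64 ug/mL in this assay, at which 3 of the 3 values shown sit, so none of the measured steps can be read in size or direction: a step that the two limits leave unreadable from compound 1 to compound 2, a step that the two limits leave unreadable from compound 1 to compound 3 and a step that the two limits leave unreadable from compound 2 to compound 3. The step that most closely resembles the change now considered is the one replacing the group on the oxygen on a saturated carbon, which is among these unreadable ones. Compound 4 `CS(=O)(=O)OC1CCC(CN2CCN(c3cc(=O)c4cc(C(F)(F)F)cc([N+](=O)[O-])c4s3)CC2)CC1` has not yet been measured in this assay. It differs from compound 3 in one place: methylsulfonyl in place of (4-methylphenyl)carbonyl on an oxygen on a saturated carbon. Since every comparable step left the reading at the limit, the expectation is for no step beyond the scatter, a step that the limit leaves unreadable from compound 3 to compound 4. Compound 4 is therefore expected to give 80 ug/mL, within a range from 40 ug/mL to 200 ug/mL, most probably again reported only as a limit.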

Compound 4, half-maximal inhibitory concentration: > 64 ug/mL
Compound 4: only a limit was reported; the forecaster's own chance of this, stated with the estimate: 85%; the middle value lies beyond the limit too.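

Compound 4 also gives only a limit, like compound 1, compound 2 and compound 3, so no step among these four compounds can be read: the limit of > 64 ug/mL in this assay, at which 4 of the 4 values shown sit.

On these data alone, how these four compounds would rank, and whether swapping the group on the oxygen changes the reading at all, stays open.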